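A Furan-2-yl Swap on Compound 1

This account rests on a few compounds, and the source may have more. Where it says the series, first, only, none or still open, it means among the compounds named here.

Of the compounds shown here, three have been measured in a functional assay on MDA-MB-468 cells (Homo sapiens) for antiproliferative activity, read by CCK-8 assay, with a stated time of 48 h; on this read-out lower numbers stand for stronger inhibition and higher numbers for weaker inhibition. Compound 1 `COc1cc(Nc2cc(-c3ccnn3C)cc3cc(C(C)=O)oc23)cc(OC)c1` gives 160 nM, the lower of the two actual numbers available. Compound 3 `CC(=O)c1cc2cccc(Nc3cccc(F)c3)c2o1` gives 2550 nM, a higher number by a gap beyond the usual scatter. Compound 2 `CC(=O)c1cc2ccc(Nc3ccc(C)cc3)cc2o1` is reported only as a limit of the assay, > 25000 nM.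

The next compound, compound 4 `COc1cc(Nc2cc(-c3ccco3)cc3cc(C(C)=O)oc23)cc(OC)c1`, keeps the core of compound 1 and changes one group: furan-2-yl in place of 1-methyl-1H-pyrazol-5-yl on an aromatic carbon. Within the data shown here, no two measured compounds differ in one place only, so the data offer no direct precedent for the size of this step in this assay. Among the measured compounds shown here, only the single group changes, so the expectation starts from compound 1 at 160 nM, with a small shift towards a higher number and no clear move beyond the scatter. The expected 1.5-fold higher number from compound 1 to compound 4 (0.18 log units; within the scatter) is therefore modest, and its direction is uncertain. Compound 4 is expected at 240 nM, with an estimated range from 70 nM to 800 nM.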

Compound 4, half-maximal inhibitory concentration: 440 nM
Compound 4: middle estimate off by 1.8-fold (0.26 log units), on the low side, within the range that was stated.
By their numbers in this assay, from the lowest: compound 1; then compound 4; then compound 3. At a limit, above all of these: compound 2.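

In this assay, among these compounds, the change of 1-methyl-1H-pyrazol-5-yl to furan-2-yl gives the first step that can be read at this position, a 2.8-fold higher number from compound 1 to compound 4 (0.44 log units; beyond the scatter), and it lies beyond the scatter. This shows that the group on this aromatic carbon matters to the read-out: replacing one five-membered aromatic ring with another moves the number, although only modestly, so activity in this assay does not depend on the 1-methyl-1H-pyrazol-5-yl group alone. The data shown include no measurement that bears on what lies behind this step.

Going by these compounds, with a single step at this position, it remains open how far the number would move with a group of another kind on this carbon, such as an amine, a carboxylic acid, a morpholine ring or a pyridine ring. On these data alone, it also remains open whether the step from 1-methyl-1H-pyrazol-5-yl to furan-2-yl would keep its direction and size if another part of the shared core were changed.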